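The compounds below may be only part of what the source reports. "The series", "measured", "known", "first", "only" and "open" are said of these compounds alone.

Measured compounds and their values in a functional assay on SGC-7901 cells (Homo sapiens) for antiproliferative activity, read by MTT assay, with a stated time of 24 h; on this read-out higher numbers stand for weaker inhibition and lower numbers for stronger inhibition:
- compound 1, `O=c1[nH]cc(S(=O)(=O)Nc2ccc(-c3cn(-c4ccccc4F)nn3)cc2)c(=O)[nH]1`: 7270 nM
- compound 2, `O=c1[nH]cc(S(=O)(=O)Nc2ccc(-c3cn(-c4cccc(F)c4)nn3)cc2)c(=O)[nH]1`: > 20000 nM
- compound 3, `O=c1[nH]cc(S(=O)(=O)Nc2ccc(-c3cn(-c4cccc(Cl)c4)nn3)cc2)c(=O)[nH]1`: 2460 nM

The value of compound 2 is a limit of the assay, not a number (the limit of > 20000 nM in this assay, at which 1 of the 3 values shown sits). Among the numbers shown, compound 3 stands lowest; the nearest is compound 1, and the step of a 3.0-fold lower number from compound 1 to compound 3 (0.47 log units; beyond the scatter) lies beyond the scatter. The step of an at least 8.1-fold lower number from compound 2 to compound 3 (0.91 log units; beyond the scatter) shows that chloro in place of fluoro gave a lower number, while an at least 2.7-fold higher number from compound 1 to compound 2 (0.43 log units; beyond the scatter) shows that moving a fluoro from one ring position to another gave a higher one.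

Compound 4, `O=c1[nH]cc(S(=O)(=O)Nc2ccc(-c3cn(-c4ccc(Cl)cc4)nn3)cc2)c(=O)[nH]1`, differs from compound 3 only by 4-chlorophenyl in place of 3-chlorophenyl on an aromatic nitrogen. Among the compounds with values here, the measured steps show that ring position matters for the fluoro compounds, but no measured step moves a chloro between positions, so the direction of the change is open. A small step, possibly within the scatter, is expected for compound 4 in this assay: a 1.3-fold higher number from compound 3 to compound 4 (0.11 log units; within the scatter). Compound 4 is estimated at 3200 nM, between 800 nM and 13000 nM.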

Compound 4, half-maximal inhibitory concentration: 1830 nM
Estimate against measurement, compound 4: 1.7-fold (0.24 log units) above; the range from low to high includes it.
By their numbers in this assay, from the lowest: compounds 4 and 3 (each within the scatter of the next); then compound 1. At a limit, above all of these: compound 2.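

In this assay, 4-chlorophenyl in place of 3-chlorophenyl gives a 1.3-fold lower number from compound 3 to compound 4 (0.13 log units; within the scatter), so these two chloro positions cannot be told apart here, unlike the two fluoro positions in compound 1 and compound 2. Compound 4 also stands clear of the compound with 2-fluorophenyl, with a 4.0-fold lower number from compound 1 to compound 4 (0.60 log units; beyond the scatter), although that change alters both the halogen and its ring position. Compound 2 carries a limit of the assay and not a number, so an at least 10-fold lower number from compound 2 to compound 4 (1.03 log units; beyond the scatter) gives only a bound: the limit of > 20000 nM in this assay, at which 1 of the 4 values shown sits.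

The compounds shown leave open how 2-chlorophenyl and 4-fluorophenyl would compare, which would complete the halogen and position pairs. Going by these compounds, it also remains open what a bromo, a methoxy or an amine would do on this phenyl ring.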